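The compounds below may be only part of what the source reports. "The series", "measured", "known", "first", "only" and "open" are said of these compounds alone.

In a functional assay on MDA-MB-231 cells (Homo sapiens) for cytotoxicity, read by MTT assay, with a stated time of 72 h (a higher number here means a weaker inhibitor, a lower number a stronger inhibitor), compound 1 `Cn1nc(-c2ccccc2)c2cc(C(=N)Nc3ccccc3)ncc21` gives 11100 nM, and compound 2 `COc1ccc(Cn2nc(-c3ccccc3)c3cc(C(=N)Nc4ccccc4)ncc32)cc1` gives 5400 nM. The change between them, (4-methoxyphenyl in place of hydrogen on a saturated chain carbon bound to an aromatic nitrogen), made a step of a 2.1-fold lower number from compound 1 to compound 2 (0.31 log units; beyond the scatter). Compound 3 `Cn1ncc2cc(C(=N)Nc3cccc(C(F)(F)F)c3)ncc21` carries a different core; the difference between the two cores is not broken down here. In this assay compound 3 reaches only the limit > 50000 nM, reported as a limit rather than a number; 1 of the 3 values shown sit at the limit of > 50000 nM in this assay, at which 1 of the 3 values shown sits. Compound 4 `COc1ccc(Cn2ncc3cc(C(=N)Nc4cccc(C(F)(F)F)c4)ncc32)cc1` bears the same change relative to compound 3, namely (4-methoxyphenyl in place of hydrogen on a saturated chain carbon bound to an aromatic nitrogen), with the place given in the same words as for the step from compound 1 to compound 2. On the basis of that single earlier step, a step of about an at least 1.1-fold lower number from compound 3 to compound 4 (0.04 log units; that floor lies within the scatter) is expected for compound 4, with the reservation that compound 3 supplies only a limit, so compound 4 may also stay at the limit. In this assay compound 4 is estimated at 45000 nM, within 15000 nM to 150000 nM.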

Compound 4, half-maximal inhibitory concentration: 29800 nM
Compound 4: the middle estimate sits 1.5-fold (0.18 log units) above what was measured, within the range that was stated.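

In this assay, the change from methyl to 4-methoxybenzyl on the core of compound 3 gives an at least 1.6-fold lower number from compound 3 to compound 4 (0.22 log units; that floor lies within the scatter). Compound 3 stands at > 50000 nM, a limit and not a number, so this step has only a floor. The result fits the change carrying over from the core of compound 1 but does not establish it, and two pairs give no rule for other cores: the same change on two cores in this assay, a 2.1-fold lower number (0.31 log units; beyond the scatter) from compound 1 to compound 2 and an at least 1.6-fold lower number (0.22 log units; that floor lies within the scatter) from compound 3 to compound 4; the limit leaves it open whether they differ

As far as these compounds go, whether a plain benzyl or a longer chain at this place gives a step of like size stays open. Also open, from the compounds shown here alone, is how far the phenyl and the trifluoromethyl, which separate the two pairs, each contribute.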